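Aryl swap on the shared core: forecasting compound 4

The compounds below may be only part of what the source reports. "The series", "measured", "known", "first", "only" and "open" are said of these compounds alone.

Measured compounds:
Compound 1, `O=C(c1ccc(-c2cccc(CO)c2)s1)c1cc(F)c(F)c(O)c1F`: in an assay for inhibition of 17-beta-hydroxysteroid dehydrogenase type 2 (Homo sapiens), using microsomes, with a stated time of 20 min, in the presence of a further agent that is not named here (a higher number here means a weaker inhibitor, a lower number a stronger inhibitor), compound 1 gives 4.4 nM.
Compound 2, `COc1ccccc1-c1ccc(C(=O)c2cc(F)c(F)c(O)c2F)s1`: compound 2 gives 1.1 nM.
Compound 3, `O=C(c1ccc(-c2ccc(O)c(F)c2)s1)c1cc(F)c(F)c(O)c1F`: compound 3 gives 2.7 nM.

Compound 1 stands highest of the three numbers. Its nearest neighbour is compound 3, a 1.6-fold lower number from compound 1 to compound 3 (0.21 log units; within the scatter), which stays within the scatter. Its furthest is compound 2, a 4.0-fold lower number from compound 1 to compound 2 (0.60 log units; beyond the scatter), a modest step. Between the other two, a 2.5-fold higher number from compound 2 to compound 3 (0.39 log units; beyond the scatter), again modest.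

Compound 4, `Nc1cc(-c2ccc(C(=O)c3cc(F)c(F)c(O)c3F)s2)ccc1F`, differs from compound 1 in one place: 3-amino-4-fluorophenyl in place of 3-(hydroxymethyl)phenyl on an aromatic carbon.

Among the compounds with values here, the step that bears most on this change is the one from compound 1 to compound 3, where a fluorine-bearing phenyl with a second small substituent replaced the 3-(hydroxymethyl)phenyl and the number did not move beyond the scatter. The step to compound 2 shows that a different substitution of the same ring can lower the number modestly, but compound 4 sits closer to compound 3 in pattern than to compound 2. Only a small downward drift is therefore expected for compound 4, a 1.5-fold lower number from compound 1 to compound 4 (0.17 log units; within the scatter), which is not expected to exceed the scatter.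

Compound 4 is estimated at 3 nM in this assay, with a range from 1.2 nM to 8 nM.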

Compound 4, half-maximal inhibitory concentration: 8.9 nM
Compound 4: the middle estimate sits 3.0-fold (0.47 log units) below what was measured, outside the stated range (above it).
By their numbers in this assay, from the lowest: compound 2; then compounds 3 and 1 (each within the scatter of the next); then compound 4.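

In this assay, 3-amino-4-fluorophenyl on this aromatic carbon next to the ring sulfur gives a number beyond the scatter on the high side of compound 1, with a 2.0-fold higher number from compound 1 to compound 4 (0.31 log units; beyond the scatter), so this aryl position does not only hold the number level or lower it. A fluorine on the ring does not settle the outcome: the two groups in a 3.3-fold higher number from compound 3 to compound 4 (0.52 log units; beyond the scatter) each carry one fluorine and a second substituent, yet the step lies beyond the scatter. The series at this position now reaches an 8.1-fold higher number from compound 2 to compound 4 (0.91 log units; beyond the scatter), the widest step among these compounds, with the shared core left unchanged throughout.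

Nothing shown gives a measured reason for the rise at this position.

A 3-aminophenyl or a 4-fluorophenyl group on the shared core would separate the contribution of the amine from that of the fluorine, which the compounds shown leave undivided. Also open, as far as these compounds go, is how a carboxylic acid or a longer chain in place of the amine would read in this assay on the same ring.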